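The source may report more compounds than this note shows. Statements on the series, on what has been measured and on what is new or still open speak of the compounds shown alone.

Measured in an ADME assay on HEK293 cells (Homo sapiens) for cytotoxicity, read by resazurin assay, with a stated time of 48 h; a higher number here means that more compound is tolerated, a lower number that less compound is tolerated:
- compound 1 `COc1ccc(S(=O)(=O)Nc2ccc(-c3nc4cc(NS(=O)(=O)c5ccc(OC)cc5)ccc4o3)cc2)cc1`: 48000 nM
- compound 2 `O=S(=O)(Nc1ccc(-c2nc3cc(NS(=O)(=O)c4ccccc4Cl)ccc3o2)cc1)c1ccccc1Cl`: 46000 nM

Only these two compounds have been measured, and they lie within the usual scatter of each other, so compound 1 does not stand apart from compound 2. Compound 3 `COc1ccc(S(=O)(=O)Nc2ccc3oc(-c4ccc(NS(=O)(=O)c5cc(F)ccc5OC)cc4)nc3c2)cc1` has not yet been measured. It differs from compound 1 in one place: 5-fluoro-2-methoxyphenyl in place of 4-methoxyphenyl on a sulfonyl sulfur. In words, 5-fluoro-2-methoxyphenyl stands in place of 4-methoxyphenyl on a sulfonyl sulfur. Among the measured compounds shown here, no measured pair isolates a change of this kind, so the data offer no direct guide to its size. For the measured compounds named here, the only guide is that compound 2, at 46000 nM, falls within the scatter of compound 1, at 48000 nM. No step beyond the scatter is therefore expected in this assay, in either direction. The estimated change is a 1.1-fold lower number from compound 1 to compound 3 (0.06 log units; within the scatter). For compound 3 the expected value is 42000 nM, with an estimated range from 20000 nM to 85000 nM.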

Compound 3, half-maximal cytotoxic concentration: 24000 nM
Estimate against measurement, compound 3: 1.8-fold (0.24 log units) above; low and high end bracket the measured number.
By their numbers in this assay, from the lowest: compounds 3, 2 and 1 (each within the scatter of the next).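

In this assay, among the compounds shown here, the replacement of 4-methoxyphenyl by 5-fluoro-2-methoxyphenyl on a sulfonyl sulfur gives the first reading of a change in one place: a 2.0-fold lower number from compound 1 to compound 3 (0.30 log units; within the scatter). This step lies at the edge of the usual scatter but not beyond it, so the position takes this substituted ring without a demonstrated change in how much compound the cells tolerate. Nothing available on these compounds offers an explanation for the size of this step.

The compounds shown leave open how much of the step belongs to the fluorine and how much to the new place of the methoxy group, which a 2-methoxyphenyl group on the same sulfur would help to separate. They also leave open how the position would respond to a group of another kind, such as an amine or a carboxylic acid.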